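Compound 3: a 4-bromobutyl chain on the carbonyl carbon

This account rests on a few compounds, and the source may have more. Where it says the series, first, only, none or still open, it means among the compounds named here.

Of the compounds shown here, two on the shared core have been read so far in a functional assay on A549 cells (Homo sapiens) for cytotoxicity, read by MTT assay, with a stated time of 48 h; a lower number here means a stronger inhibitor, a higher number a weaker inhibitor. Compound 1 `C=C1C(=O)O[C@H]2CC3=C[C@H](C/C(C)=C/[C@@H](OC(=O)/C=C/c4ccc(N(C)C)cc4)[C@H]12)OC3=O` reports only a limit, > 10000 nM. Among the compounds with values here, compound 2 `C=C1C(=O)O[C@H]2CC3=C[C@H](C/C(C)=C/[C@@H](OC(=O)/C=C/c4cccc(OC)c4)[C@H]12)OC3=O` gives 6200 nM, the only actual number. Within the data shown here, the one measured step, an at least 1.6-fold lower number from compound 1 to compound 2 (0.20 log units; that floor lies within the scatter), places 3-methoxyphenyl where 4-(dimethylamino)phenyl stood, and it does not establish a change beyond the scatter. One end of that step rests on (the limit of > 10000 nM in this assay, at which 1 of the 2 values shown sits).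

Compound 3 `C=C1C(=O)O[C@H]2CC3=C[C@H](C/C(C)=C/[C@@H](OC(=O)CCCCBr)[C@H]12)OC3=O` changes more: 4-bromobutyl in place of 2-(3-methoxyphenyl)ethenyl on a carbonyl carbon. That is 4-bromobutyl in place of 2-(3-methoxyphenyl)ethenyl on a carbonyl carbon, so the aromatic ring present in both measured compounds is gone. Among the measured compounds shown here, no measured step covers such a replacement, and the step from compound 1 offers only weak guidance. No shift beyond the scatter is therefore expected in either direction in this assay, though the uncertainty is wide. The expected change is a 1.0-fold lower number from compound 2 to compound 3 (0.01 log units; within the scatter). Compound 3 is estimated at 6000 nM, with an expected range of 2000 nM to 18000 nM.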

Compound 3, half-maximal inhibitory concentration: > 10000 nM
Compound 3: no number, only a limit (the forecaster's own chance of this, stated with the estimate: 25%); middle value at least 1.6-fold (0.22 log units) from the limit.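

In this assay, 4-bromobutyl in place of 2-(3-methoxyphenyl)ethenyl on the carbonyl carbon gives an at least 1.6-fold higher number from compound 2 to compound 3 (0.20 log units; that floor lies within the scatter), so this replacement shows no gain in the read-out, while a loss beyond the scatter is not established. Of the changes shown at this position, it alone removes the aromatic ring and the double bond outside it, and the result for compound 3 is a limit, not a number, as for compound 1; the step between those two cannot be read. The one actual number in the series thus remains that of compound 2, and what can be said about this position is bounded by the following: the limit of > 10000 nM in this assay, at which 2 of the 3 values shown sit.

The compounds shown leave open whether the loss of the aromatic ring or the chain itself governs the result, and a plain phenyl ring on the ethenyl chain or a longer alkyl chain would bear on that. They also leave open what the bromine contributes, which a plain butyl chain or a butyl chain ending in an amine or a carboxylic acid would address.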